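A methyl for fluoro at the edge of the range

This account rests on a few compounds, and the source may have more. Where it says the series, first, only, none or still open, it means among the compounds named here.

In an ADME assay on L6 cells (Rattus norvegicus) for cytotoxicity, read by resazurin assay, with a stated time of 72 h (a lower number here means a stronger inhibitor, a higher number a weaker inhibitor), compound 1 (`OC(c1ccc(Cl)cc1)(c1cncnc1)c1ccccc1F`) gives > 100000 nM as a limit of the assay and not a number. Compound 2 (`OC(c1ccc(Cl)cc1)(c1cccnc1)c1ccccc1F`) gives > 100000 nM in the same assay, and this too is a limit. Compound 2 therefore stands at the limit of > 100000 nM in this assay, at which 2 of the 3 values shown sit, and has no exact value to build on. Compound 3 (`Clc1ccc(C(c2ccc(Cl)cc2)c2cncnc2)cc1`) gives a true number, 70100 nM in this assay as well.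

Compound 4 (`Cc1ccccc1C(O)(c1ccc(Cl)cc1)c1cccnc1`) has not yet been measured. It carries methyl in place of fluoro on an aromatic carbon, so that 2-fluorophenyl becomes 2-methylphenyl (methyl in place of fluoro on an aromatic carbon). Within the data shown here, the only measured single-place step is a step that the two limits leave unreadable from compound 1 to compound 2 and it concerns another part of the molecule, so it offers no size to carry over.

Among the measured compounds shown here, no large step is therefore expected, and any direction is tentative. A number can occur among these compounds, as compound 3 shows with 70100 nM in that assay. A reading under the limit therefore remains possible for compound 4. The expected change is an at least 1.1-fold lower number from compound 2 to compound 4 (0.07 log units; that floor lies within the scatter) and it is estimated to be small. For compound 4 the estimated value is 85000 nM with an expected range from 40000 nM to 100000 nM in this assay.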

Compound 4, half-maximal inhibitory concentration: 82000 nM
The estimate for compound 4 lay 1.0-fold (0.02 log units) above the measured number; the range from low to high includes it.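

In this assay, the change from 2-fluorophenyl to 2-methylphenyl gives an at least 1.2-fold lower number from compound 2 to compound 4 (0.08 log units; that floor lies within the scatter). The step between compound 1 and compound 2 cannot be read, which makes this the only step among the compounds shown with any stated size, and it shows that a change on this aromatic carbon, ortho to a large group, can bring a compound with pyridin-3-yl to a true number, with compound 4 at 82000 nM. Compound 2 gives only a limit of the assay and not a number, so the step has a floor but no exact size: the limit of > 100000 nM in this assay, at which 2 of the 4 values shown sit.

The compounds shown leave open how other groups at this place, such as chloro, methoxy, trifluoromethyl or an amine, would read in this assay, and whether a longer chain such as ethyl would give a number close to that of compound 4 or a clearly different one. On these data alone, it also remains open whether methyl in place of fluoro would give a true number on the core of compound 1, which carries pyrimidin-5-yl instead of pyridin-3-yl.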